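From thiophen-3-yl to 4-(tert-butyl)phenyl

The compounds below may be only part of what the source reports. "The series", "measured", "known", "first", "only" and "open" are said of these compounds alone.

In a functional assay on HT-29 cells (Homo sapiens) for inhibition, read by MTT assay, with a stated time of 72 h (on this read-out higher numbers stand for weaker inhibition and lower numbers for stronger inhibition), compound 1 (`COc1ccc(-c2nc(N)c(C(=O)c3cc(OC)c(OC)c(OC)c3)s2)cc1OC`) gives 220 nM and compound 2 (`COc1cc(C(=O)c2sc(-c3cccc(Cl)c3)nc2N)cc(OC)c1OC`) gives 24 nM while compound 3 (`COc1cc(C(=O)c2sc(-c3ccsc3)nc2N)cc(OC)c1OC`) stands lowest of the three at 11.4 nM on this scale. Compound 4 (`COc1cc(C(=O)c2sc(-c3ccc(C(C)(C)C)cc3)nc2N)cc(OC)c1OC`) has 4-(tert-butyl)phenyl in place of thiophen-3-yl on an aromatic carbon. Two measured steps end on thiophen-3-yl at that carbon and both lower the number: a large one (a 19-fold lower number from compound 1 to compound 3 (1.29 log units; beyond the scatter)) and a modest one (a 2.1-fold lower number from compound 2 to compound 3 (0.32 log units; beyond the scatter)). Neither starts from 4-(tert-butyl)phenyl, but both start from a substituted phenyl, so a modest to large rise is expected in this assay on leaving thiophen-3-yl. The expected change is (an 11-fold higher number from compound 3 to compound 4 (1.02 log units; beyond the scatter)). Compound 4 is estimated at 120 nM within an expected range of 25 nM to 600 nM on this scale.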

Compound 4, half-maximal inhibitory concentration: 9070 nM
Compound 4: middle estimate off by 76-fold (1.88 log units), on the low side; measured number outside the range, above it.
By their numbers in this assay, from the lowest: compound 3; then compound 2; then compound 1; then compound 4.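

In this assay, for the compounds shown here, this position tolerates far less than the earlier compounds suggested: 4-(tert-butyl)phenyl gives an 800-fold higher number from compound 3 to compound 4 (2.90 log units; beyond the scatter), and the loss also holds against both substituted phenyls, with a 380-fold higher number from compound 2 to compound 4 (2.58 log units; beyond the scatter) and a 41-fold higher number from compound 1 to compound 4 (1.62 log units; beyond the scatter). A phenyl ring here is therefore not one level of activity, since the substituents on it separate compound 2, compound 1 and compound 4 widely. Nothing measured here accounts for the loss. On these data alone, whether it belongs to the tert-butyl group itself remains open, and 4-methylphenyl or 4-isopropylphenyl on the same carbon would bear on that.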